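A few compounds are considered here, and "the series" means these few. Any claim that something is new, unique, unknown or untested is made for them only; others in the source may bear on it.

In a functional assay on SH-SY5Y cells (Homo sapiens) for cytotoxicity, read by MTT assay, with a stated time of 56 h (a higher number here means that more compound is needed for the effect, a lower number that less compound is needed), compound 1 (`c1ccc(-c2ccccc2-c2cn(CCCCCCn3cc(-c4cccnc4)nn3)nn2)cc1`) gives 36.6 nM and compound 2 (`c1ccc(-c2ccccc2-n2cc(CCCCCCCn3cc(-c4cccnc4)nn3)nn2)cc1`) gives 55.1 nM as its reading. These two values lie within the usual scatter of each other, so compound 2 stands level with compound 1 on the numbers available. Compound 3 (`c1ccc(-c2ccccc2-n2cc(CCCCCCCc3cn(-c4cccnc4)nn3)nn2)cc1`) has the same atoms as compound 2, joined differently (1-(pyridin-3-yl)-1H-1,2,3-triazol-4-yl in place of 4-(pyridin-3-yl)-1H-1,2,3-triazol-1-yl on a saturated chain carbon, seven bonds along the chain from an aromatic carbon): 1-(pyridin-3-yl)-1H-1,2,3-triazol-4-yl sits in place of 4-(pyridin-3-yl)-1H-1,2,3-triazol-1-yl on a saturated chain carbon, seven bonds along the chain from an aromatic carbon. No measured step shows what such a change does in this assay for any of these compounds, so no shift beyond the scatter is expected, in either direction. The expected step (a 1.1-fold lower number from compound 2 to compound 3 (0.04 log units; within the scatter)) is therefore small. Compound 3 is estimated at 50 nM with 20 nM to 130 nM as its expected range.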

Compound 3, half-maximal effective concentration: > 500 nM
Compound 3: a limit, no number (the forecaster's own chance of this, stated with the estimate: 3%); middle value at least 10-fold (1.00 log units) from the limit.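

In this assay, 1-(pyridin-3-yl)-1H-1,2,3-triazol-4-yl in place of 4-(pyridin-3-yl)-1H-1,2,3-triazol-1-yl on a saturated chain carbon, seven bonds along the chain from an aromatic carbon, gives an at least 9.0-fold higher number from compound 2 to compound 3 (0.95 log units; beyond the scatter). On these data alone, compound 3 carries a limit and not a number, so the full size of this step stays unknown: the limit of > 500 nM in this assay, at which 1 of the 3 values shown sits. The two groups hold the same atoms, joined differently, so the way they are joined at this place is enough to move the reading beyond the scatter, which compound 1 and compound 2 alone did not show.

As far as these compounds go, it remains open whether the same exchange would act alike in compound 1. Also open, from the compounds shown here alone, is how a longer chain, or an amine or a carboxylic acid on the pyridin-3-yl group, would read in this assay.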